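Four Configurations, One Cytotoxicity Read-Out

The compounds below may be only part of what the source reports. "The series", "measured", "known", "first", "only" and "open" are said of these compounds alone.

Three isomers were measured in an ADME assay on Akata cells (Homo sapiens) for cytotoxicity (on this read-out higher numbers stand for lower toxicity in this test and lower numbers for higher toxicity in this test), and gave these values:

Compound 1 `Nc1ncnc2c1ncn2/C=C1\C[C@@H]1[C@H](O)CO` gives 57000 nM
Compound 2 `Nc1ncnc2c1ncn2/C=C1\C[C@H]1[C@@H](O)CO` gives 73000 nM
Compound 3 `Nc1ncnc2c1ncn2/C=C1/C[C@H]1[C@@H](O)CO` gives 61500 nM

The three share the same atoms and bonds and differ only in configuration as drawn. Compound 3, at 61500 nM, lies within the scatter of both other compounds, so it holds no distinct place among them.

The next isomer is compound 4 `Nc1ncnc2c1ncn2/C=C1/C[C@@H]1[C@@H](O)CO`. The change from compound 3 is the two compounds have the same atoms and bonds and differ only in configuration as drawn: 1 of 3 stereo elements differ; a stereocentre at a saturated ring carbon is drawn R in compound 3 and S in compound 4, and nothing leaves or enters. Going by the values given here, no measured step alters that ring stereocentre alone. The nearest is a 1.3-fold higher number from compound 1 to compound 2 (0.11 log units; within the scatter), which alters it together with a stereocentre at a saturated chain carbon. Changing the double bond alone gave a 1.2-fold lower number from compound 2 to compound 3 (0.07 log units; within the scatter), and changing all three stereo elements gave a 1.1-fold higher number from compound 1 to compound 3 (0.03 log units; within the scatter). None of these steps in this assay goes beyond the scatter, so no step beyond the scatter is expected here, in either direction. The combination of configurations in compound 4 is itself untested, which keeps the range wide.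

The expected step is a 1.0-fold lower number from compound 3 to compound 4 (0.01 log units; within the scatter) and thus stays within the scatter.

For compound 4 the estimated value is 60000 nM, with an expected range from 32000 nM to 100000 nM.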

Compound 4, half-maximal cytotoxic concentration: 55000 nM
For compound 4 the middle estimate is 1.1-fold (0.04 log units) above the measured one; the measured number falls inside the stated range.
By their numbers in this assay, from the lowest: compounds 4, 1, 3 and 2 (each within the scatter of the next).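

In this assay, going by these compounds alone, the ring stereocentre changes on its own for the first time, giving a 1.1-fold lower number from compound 3 to compound 4 (0.05 log units; within the scatter), and this step can be read for that stereocentre alone because no other feature changes: the fact that compounds 3 and 4 differ only in the configuration as drawn Two further pairs add combinations not seen before: changing the ring stereocentre together with the double bond gives a 1.3-fold lower number from compound 2 to compound 4 (0.12 log units; within the scatter), while changing the chain stereocentre together with the double bond gives a 1.0-fold lower number from compound 1 to compound 4 (0.02 log units; within the scatter). With these steps, all the printed comparisons among the four configurations stay within the scatter, so neither the ring stereocentre alone nor either of these paired changes separates the compounds on this read-out.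

Within the data shown here, the four compounds offer no pair in which the chain stereocentre differs on its own, so its separate contribution remains open. They also leave open whether a carboxylic acid or a longer chain on the shared core would give a step beyond the scatter in this assay, since all four compounds have the same atoms and bonds.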